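Two Hydroxyls Removed from the Sulfur-Bound Chain

The source may report more compounds than this note shows. Statements on the series, on what has been measured and on what is new or still open speak of the compounds shown alone.

Among the compounds with values here, compound 2 `CC(C)c1n[nH]c2c(NCc3ccc(-c4ccccn4)cc3)nc(SCC(O)CO)nc12` gives the lowest number of the two measured so far in a functional assay on HT cells (Homo sapiens) for antiproliferative activity, read by fluorescence, with a stated time of 72 h (on this read-out higher numbers stand for weaker inhibition of growth and lower numbers for stronger inhibition of growth), at 21 nM. Its nearest neighbour is compound 1 `CCC(O)CSc1nc(NCc2ccc(-c3ccccn3)cc2)c2[nH]nc(C(C)C)c2n1`, which in this assay gives 273 nM; the step of a 13-fold lower number from compound 1 to compound 2 (1.11 log units; beyond the scatter) came from hydroxy in place of methyl on a saturated chain carbon, two bonds along the chain from an oxygen on a saturated carbon. Compound 3 `COCSc1nc(NCc2ccc(-c3ccccn3)cc2)c2[nH]nc(C(C)C)c2n1` goes the other way: methoxy in place of 1,2-dihydroxyethyl on a saturated chain carbon bound to a sulfur. This removes the hydroxy whose arrival brought that large step, and the second hydroxy with it, leaving only a methoxy on the saturated chain carbon bound to a sulfur. Within the data shown here, the one measured step that bears on this is a 13-fold lower number from compound 1 to compound 2 (1.11 log units; beyond the scatter), so for compound 3 an upward step of at least that size is expected, a 21-fold higher number from compound 2 to compound 3 (1.33 log units; beyond the scatter). Compound 3 is therefore estimated at about 450 nM in this assay, within a range of 120 nM to 1700 nM.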

Compound 3, concentration for 50% growth inhibition: 340 nM
Beside the measured number, compound 3's estimate is 1.3-fold (0.12 log units) above it; measured number inside the range.
By their numbers in this assay, from the lowest: compound 2; then compounds 1 and 3 (each within the scatter of the next).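

In this assay, putting methoxy in place of 1,2-dihydroxyethyl on a saturated chain carbon bound to a sulfur gives a 16-fold higher number from compound 2 to compound 3 (1.21 log units; beyond the scatter), which undoes nearly all of the advantage of compound 2. Putting methoxy in place of 1-hydroxypropyl at the same carbon gives a 1.2-fold higher number from compound 1 to compound 3 (0.10 log units; within the scatter), so these two chains cannot be told apart, and among these three compounds only the chain of compound 2 stands out. No accompanying measurement accounts for this difference.

The compounds shown leave open whether both hydroxy groups are needed, since a 2-hydroxyethyl group at this carbon would separate the contribution of one from that of the pair. They also leave open whether an amine or a carboxylic acid there could match the 1,2-dihydroxyethyl group.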